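A few compounds are considered here, and "the series" means these few. Any claim that something is new, unique, unknown or untested is made for them only; others in the source may bear on it.

Within the data shown here, compound 1 `Cn1nc2c(=O)n(CC3(O)CCN(Cc4ccc(-c5ccco5)cc4Cl)CC3)cnc2c1-c1ccc(CNC(=O)C(F)(F)F)cc1` is the weaker of the two compounds measured so far. In an assay on isolated protein for inhibition of ubiquitin carboxyl-terminal hydrolase 7 (Homo sapiens), with stated times of 30 min and 2 h (on this read-out higher numbers stand for weaker inhibition and lower numbers for stronger inhibition), compound 1 gives 2060 nM, the highest of the two numbers. Compound 2 `Cn1nc2c(=O)n(CC3(O)CCN(Cc4ccc(-n5ccnc5)cc4Cl)CC3)cnc2c1-c1ccc(CN)cc1` gives 228 nM in this assay, a number beyond the usual scatter below that of compound 1; compound 2 differs from compound 1 in more than one place, so its value shows only where the pair stands and not the effect of any single change. Compound 3 `Cn1nc2c(=O)n(CC3(O)CCN(Cc4ccc(-c5ccco5)cc4Cl)CC3)cnc2c1-c1ccc(Cl)cc1` has not yet been measured. It arises from compound 1 through one change: chloro in place of (((trifluoromethyl)carbonyl)amino)methyl on an aromatic carbon, chloro in place of (((trifluoromethyl)carbonyl)amino)methyl, sitting para to a large group. Among the measured compounds shown here, no measured pair shows this exact exchange, so the step has to be estimated. The step of a 1.2-fold higher number from compound 1 to compound 3 (0.08 log units; within the scatter) is expected to be small, within the scatter or slightly toward weaker inhibition. Compound 3 is therefore estimated at 2500 nM in this assay, with a range from 800 nM to 8000 nM.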

Compound 3, half-maximal inhibitory concentration: 143 nM
The estimate for compound 3 lay 17-fold (1.24 log units) above the measured number; measured number outside the range, below it.
By their numbers in this assay, from the lowest: compounds 3 and 2 (each within the scatter of the next); then compound 1.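

On this aromatic carbon, para to a large group, the change matters a great deal: chloro in place of (((trifluoromethyl)carbonyl)amino)methyl gives a 14-fold lower number from compound 1 to compound 3 (1.16 log units; beyond the scatter) in this assay. The earlier compounds shown here could not show this, since compounds 1 and 2 differ in more than one place and so isolate no single change. This step shows that, on the core of compound 1, the hydrogen-bond donor and acceptor of the departing group are not needed for inhibition at this level, and that a single chlorine atom can take the place of its 8 heavy atoms.

Size and donor and acceptor count change together in this one pair, and no measurement available here explains the step. Going by these compounds, how other groups on this carbon, such as fluoro, methyl, a nitrile or a carboxylic acid, would compare with chloro remains open.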